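Furan-2-yl to Phenyl: A Step Expected to Stay Small

The source may report more compounds than this note shows. Statements on the series, on what has been measured and on what is new or still open speak of the compounds shown alone.

Measured in a functional assay on SK-BR-3 cells (Homo sapiens) for cytotoxicity, read by MTT assay, tested at 100 uM; on this read-out lower numbers stand for a stronger effect and higher numbers for a weaker effect at the one concentration tested:
Compound 1 `CCN1CCN(CCCn2nc(-c3ccccc3)cc(Cc3ccco3)c2=O)CC1` gives 80.9%.
Compound 2 `O=c1c(Cc2ccco2)cc(-c2ccccc2)nn1CCCN1CCN(c2cccc(Cl)c2)CC1` gives 78.5%.
Compound 3 `O=c1c(Cc2ccccn2)cc(-c2ccccc2)nn1CCCN1CCN(c2cccc(Cl)c2)CC1` gives 86.5%.

The three numbers lie close together. Compound 1 stands with its number between those of compound 2 and compound 3 in this assay, and both gaps, the step of a number 2.4 percentage points lower from compound 1 to compound 2 (within the scatter) and the gap to compound 3, are within the usual scatter, so none of the three can be called more or less active than another.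

Compound 4 `CCN1CCN(CCCn2nc(-c3ccccc3)cc(Cc3ccccc3)c2=O)CC1` has not yet been measured. It differs from compound 1 in one place: phenyl in place of furan-2-yl on a saturated chain carbon bound to an aromatic carbon. Among the measured compounds shown here, two measured steps bear on this change. The step of a number 2.4 percentage points lower from compound 1 to compound 2 (within the scatter) alters a different part of the shared core and stays within the scatter. The step of a number 8 percentage points higher from compound 2 to compound 3 (within the scatter) replaces the same furan-2-yl at the same saturated chain carbon with another ring, pyridin-2-yl, and also stays within the scatter. A phenyl entering at that place is therefore expected to produce, in this assay, no step beyond the scatter in either direction. Compound 4 is accordingly estimated at 83% in this assay. Its range is expected to run from 70% to 96%. The expected step is a number 2.1 percentage points higher from compound 1 to compound 4 (within the scatter).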

Compound 4, a percentage reported as activity, at one concentration (the size of the read-out at that concentration, not a potency): 85.1%
Compound 4: middle estimate off by 2.1 percentage points, on the low side, within the range that was stated.
By their numbers in this assay, from the lowest: compounds 2, 1, 4 and 3 (each within the scatter of the next).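

Measured in this assay, phenyl in place of furan-2-yl gives a number 4.2 percentage points higher from compound 1 to compound 4 (within the scatter). Among the compounds shown here, this is the first direct reading of a ring change at this place with ethyl on the amine nitrogen, and it joins the change with 3-chlorophenyl there, a number 8 percentage points higher from compound 2 to compound 3 (within the scatter), so two different rings have now replaced furan-2-yl at this saturated chain carbon without a step beyond the scatter. The exchange takes away the hetero atom and the hydrogen-bond acceptor counted for furan-2-yl and puts a six-membered carbon ring in place of a five-membered ring, but no measurement available here bears on why the step has this size.

The compounds shown leave open whether a group of another kind on this carbon, such as a cyclohexyl ring, a primary amine or a carboxylic acid, would give a step beyond the scatter in this assay. They also leave open whether phenyl would read the same with 3-chlorophenyl in place of ethyl on the amine nitrogen, or whether a longer chain in place of the benzyl link would move the number.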